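Replacing the dimethylamino ring of a growth inhibitor

The compounds below may be only part of what the source reports. "The series", "measured", "known", "first", "only" and "open" are said of these compounds alone.

- compound 1 (`O=C(O)c1ccc(/C=C(/SCc2ccc(Cl)cc2)C(=O)c2ccc(C(=O)O)cc2)cc1`): > 100000 nM (a limit)
- compound 2 (`CN(C)c1ccc(/C=C(/SCc2ccc(Cl)cc2)C(=O)c2ccc(C(=O)O)cc2)cc1`): 1000 nM

Among the compounds with values here, in a functional assay on DU-145 cells (Homo sapiens) for inhibition, read by trypan blue exclusion, with a stated time of 96 h (on this read-out higher numbers stand for weaker inhibition of growth and lower numbers for stronger inhibition of growth), compound 2 gives 1000 nM and holds the only true number so far. Compound 1 reads > 100000 nM and this is a limit, not a number.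

The next compound is compound 3 (`O=C(O)c1ccc(C(=O)/C(=C\c2ccc(Cl)c([N+](=O)[O-])c2)SCc2ccc(Cl)cc2)cc1`). Its change from compound 2 is this: 4-chloro-3-nitrophenyl in place of 4-(dimethylamino)phenyl on a double-bonded chain carbon bound to a double-bonded chain carbon. Within the data shown here, one measured step bears on it, an at least 100-fold lower number from compound 1 to compound 2 (2.00 log units; beyond the scatter), which put dimethylamino in place of carboxy on the same ring and was large. Compound 3 loses that dimethylamino group, but no carboxy returns. Among the measured compounds shown here, with an at least 100-fold lower number from compound 1 to compound 2 (2.00 log units; beyond the scatter) as the only guide, part of that large step is expected to be undone, toward weaker inhibition of growth in this assay. The expected step is a 6.0-fold higher number from compound 2 to compound 3 (0.78 log units; beyond the scatter). For compound 3 the estimated value is 6000 nM, with an expected range from 1000 nM to 40000 nM.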

Compound 3, concentration for 50% growth inhibition: 1000 nM
The estimate for compound 3 lay 6.0-fold (0.78 log units) above the measured number; the measured number falls inside the stated range.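

Putting 4-chloro-3-nitrophenyl in place of 4-(dimethylamino)phenyl gives no change at the digits printed from compound 2 to compound 3 (within the scatter) in this assay, so this place on the double-bonded chain carbon keeps its growth inhibition without the dimethylamino group. The earlier large step therefore does not require dimethylamino in particular: a second, quite different ring also gives a large step away from 4-carboxyphenyl, namely an at least 100-fold lower number from compound 1 to compound 3 (2.00 log units; beyond the scatter). Compound 1 stands at a limit, not a number: the limit of > 100000 nM in this assay, at which 1 of the 3 values shown sits.

The compounds shown leave open whether the chlorine, the nitro group or both matter in the new ring, and a plain phenyl ring or a ring carrying only one of them would begin to separate these. From the compounds shown here alone, how a methoxy group or a primary amine would read at this place also remains unknown.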